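Methyl to phenyl on the ring nitrogen: an expected step

This account rests on a few compounds, and the source may have more. Where it says the series, first, only, none or still open, it means among the compounds named here.

Three compounds have been measured in a functional assay on A-375 cells (Homo sapiens) for antiproliferative activity, read by trypan blue exclusion, with a stated time of 48 h, tested at 5 uM; on this read-out lower numbers stand for a stronger effect and higher numbers for a weaker effect at the one concentration tested:

compound 1 `CCCCCCC#Cc1ccc(S(=O)(=O)Nc2cccc(-c3csc(NC(C)=O)n3)c2)cc1`: 12.8%
compound 2 `CC(=O)Nc1nc(-c2cccc(NS(=O)(=O)c3ccc(C#C[Si](C)(C)C)cc3)c2)cs1`: 4.2%
compound 3 `CCCCCCC#Cc1ccc(S(=O)(=O)Nc2cccc(-c3csc(NC)n3)c2)cc1`: 8.1%

Compound 3 stands second highest of the three, nearest compound 2 and furthest compound 1, and both gaps are within the scatter. Compound 4 `CCCCCCC#Cc1ccc(S(=O)(=O)Nc2cccc(-c3csc(Nc4ccccc4)n3)c2)cc1` differs from compound 3 in one place: phenyl in place of methyl on a nitrogen on an aromatic ring. Going by the values given here, no measured step exchanges a substituent on this nitrogen for a ring. The two known steps, a number 8.6 percentage points lower from compound 1 to compound 2 (within the scatter) and a number 4.7 percentage points lower from compound 1 to compound 3 (within the scatter), each stayed within the scatter, and the second of them touched the same nitrogen. Compound 4 is therefore expected to show a number 1.9 percentage points higher from compound 3 to compound 4 (within the scatter), nothing beyond the scatter. The estimate for compound 4 is 10%, within the range 2% to 25%.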

Compound 4, a percentage reported as activity, at one concentration (the size of the read-out at that concentration, not a potency): 59.2%
Compound 4: the middle estimate sits 49.2 percentage points below what was measured; the whole stated range lies below it.
By their numbers in this assay, from the lowest: compounds 2, 3 and 1 (each within the scatter of the next); then compound 4.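

In this assay the nitrogen on the aromatic ring turned out not to be indifferent to its substituent, since phenyl in place of methyl gave a number 51.1 percentage points higher from compound 3 to compound 4 (beyond the scatter) and phenyl in place of acetyl gave a number 46.4 percentage points higher from compound 1 to compound 4 (beyond the scatter) at the one concentration tested. Methyl and acetyl at this place stayed within the scatter of each other, whereas phenyl brought a clearly weaker effect. Nothing available explains this drop.

From the compounds shown here alone, it remains open whether the aromatic ring itself matters or just a larger group, which cyclohexyl or ethyl on this nitrogen could separate. Going by these compounds, how a pyridyl ring would read here is also open.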